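The source may report more compounds than this note shows. Statements on the series, on what has been measured and on what is new or still open speak of the compounds shown alone.

Measured so far in a functional assay on K562 cells (Homo sapiens) for inhibition, read by trypan blue exclusion, with a stated time of 24 h; a higher number here means a weaker inhibitor, a lower number a stronger inhibitor:
compound 1 `NC(=O)c1ccccc1NC(=O)COc1ccccc1`, 8900 nM
compound 2 `NC(=O)c1cc(Cl)ccc1NC(=O)COc1ccccc1`, 1300 nM

Among the measured compounds shown here, compound 2 holds the lowest of the two numbers; its only neighbour is compound 1, and the step of a 6.8-fold lower number from compound 1 to compound 2 (0.84 log units; beyond the scatter) lies beyond the scatter, so compound 2 is the stronger inhibitor of the pair in this assay.

Compound 3 `Cc1ccccc1OCC(=O)Nc1ccc(Cl)cc1C(N)=O` is not yet measured. It keeps the whole of compound 2 and differs only by methyl in place of hydrogen on an aromatic carbon, cut one bond further out: phenyl to 2-methylphenyl. For the measured compounds named here, no measured step touches this ring, so nothing here speaks directly to a methyl there. Going by the values given here, the single measured step, a 6.8-fold lower number from compound 1 to compound 2 (0.84 log units; beyond the scatter), concerns a chloro on the other aromatic ring and gives no guide to the present change. The expectation is therefore no step beyond the scatter, with a slight lean toward a lower number.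

Compound 3 is estimated at 1000 nM, within 400 nM to 3000 nM, which would mean an expected step of a 1.3-fold lower number from compound 2 to compound 3 (0.11 log units; within the scatter) from compound 2 to compound 3.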

Compound 3, half-maximal inhibitory concentration: 1610 nM
Compound 3: middle estimate off by 1.6-fold (0.21 log units), on the low side; the range from low to high includes it.
By their numbers in this assay, from the lowest: compounds 2 and 3 (each within the scatter of the next); then compound 1.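

In this assay, among the compounds shown here, the change from phenyl to 2-methylphenyl is the first measured change on this ring, and a 1.2-fold higher number from compound 2 to compound 3 (0.09 log units; within the scatter) shows that a methyl ortho to a large group can be accommodated without a step beyond the scatter. The level set by the chloro on the other aromatic ring, reached through a 6.8-fold lower number from compound 1 to compound 2 (0.84 log units; beyond the scatter), therefore remains in place when this methyl is added, and compound 2 and compound 3 cannot be separated in this assay. No measurement at hand explains why the added methyl leaves the number within the scatter.

A single small group at one place on this ring leaves open whether the tolerance extends to an ethyl, a methoxy, a chloro or an amine there, or to a methyl elsewhere on the same ring. As far as these compounds go, it also remains open whether any change on this ring can move the number beyond the scatter, and whether a carboxylic acid in place of the primary amide would keep the level seen with compound 2 and compound 3.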